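This account rests on a few compounds, and the source may have more. Where it says the series, first, only, none or still open, it means among the compounds named here.

The measured compounds:
Compound 1, `OCC(CO)(CO)Nc1nnc2nncn2n1`, reaches only the limit of a functional assay on MCF7 cells (Homo sapiens) for inhibition, read by MTT assay, with a stated time of 72 h; a lower number here means a stronger inhibitor, a higher number a weaker inhibitor: compound 1 gives > 100000 nM.
Compound 2, `CCCCCC(=O)N1CCN(c2nnc3nncn3n2)CC1`, in this assay gives 5260 nM.

Within the data shown here, compound 2 thus holds the only numerical result in this assay; the other compound sits at the limit of > 100000 nM in this assay, at which 1 of the 2 values shown sits, so nothing here orders compound 2 against a second measured value, and no step between measured compounds is available to size the change that follows.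

Compound 3, `CCCC(=O)N1CCN(c2nnc3nncn3n2)CC1`, is still to be measured in this assay. It differs from compound 2 by hydrogen in place of ethyl on a saturated chain carbon, three bonds along the chain from a carbonyl carbon. Among the measured compounds shown here, with the chain shortened and no measured step to draw on, a modest weakening, or no change beyond the usual scatter, is expected: the step of a 1.4-fold higher number from compound 2 to compound 3 (0.15 log units; within the scatter) is the estimate. For compound 3 a value near 7500 nM is expected, with a range from 2500 nM to 25000 nM.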

Compound 3, half-maximal inhibitory concentration: 6910 nM
The estimate for compound 3 lay 1.1-fold (0.04 log units) above the measured number; low and high end bracket the measured number.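

In this assay the series now has its first step between measured compounds, hydrogen in place of ethyl on a saturated chain carbon, three bonds along the chain from a carbonyl carbon, and this step reads a 1.3-fold higher number from compound 2 to compound 3 (0.12 log units; within the scatter). At this position, then, the pentyl chain of compound 2 and the propyl chain of compound 3 cannot be told apart in this assay, and the loss of two carbons leaves no change that can be read. Nothing measured here offers a cause for this step.

On these data alone, whether a longer chain, an amine or a carboxylic acid in place of the ethyl would also stay within the scatter remains open. The step rests on a single pair, so it does not show how the same change behaves on any other core.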